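The source may report more compounds than this note shows. Statements on the series, on what has been measured and on what is new or still open speak of the compounds shown alone.

Measured so far in an assay for inhibition of Polyunsaturated fatty acid 5-lipoxygenase (Homo sapiens), read by spectrophotometry, tested at 20 uM; a higher number here means more inhibition at the concentration tested (going by the name of the read-out), a lower number less inhibition:
compound 1 `CN(C)c1ccc(/C=C/C=C/C(=O)N2CCCCC2)cc1` gives 13.4%
compound 2 `O=C(/C=C/C=C/c1ccc(O)cc1)N1CCCCC1` gives 44.4%
compound 3 `COc1ccc(/C=C/C=C/C(=O)N2CCCCC2)cc1` gives 42.6%

Compound 3 sits second highest of the three numbers. Its nearest neighbour is compound 2, and the two values lie within the scatter of each other, as the step of a number 1.8 percentage points lower from compound 2 to compound 3 (within the scatter) shows. The furthest is compound 1: the step of a number 29.2 percentage points higher from compound 1 to compound 3 (beyond the scatter) lies beyond the scatter, as does a number 31 percentage points higher from compound 1 to compound 2 (beyond the scatter).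

Compound 4 `CC(=O)Oc1ccc(/C=C/C=C/C(=O)N2CCCCC2)cc1` is not yet measured. It differs from compound 3 in one place:
acetyl in place of methyl on an oxygen on an aromatic ring

Of the measured steps only a number 1.8 percentage points lower from compound 2 to compound 3 (within the scatter) touches the same oxygen, and it stayed within the scatter. The two large steps, a number 31 percentage points higher from compound 1 to compound 2 (beyond the scatter) and a number 29.2 percentage points higher from compound 1 to compound 3 (beyond the scatter), concern the exchange of dimethylamino for an oxygen-bearing group and do not speak to what is carried on that oxygen. For the measured compounds named here, with only one step at this position, and that one flat, no step beyond the scatter is expected in this assay; the estimated move is a number 2.6 percentage points lower from compound 3 to compound 4 (within the scatter), in no particular direction. Compound 4 is therefore expected at about 40%, with a range from 25% to 55%.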

Compound 4, a percentage reported as inhibition, at one concentration (the size of the read-out at that concentration, not a potency): 18.3%
Compound 4: the middle estimate sits 21.7 percentage points above what was measured; measured number outside the range, below it.
By their numbers in this assay, from the lowest: compounds 1 and 4 (each within the scatter of the next); then compounds 3 and 2 (each within the scatter of the next).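

On an oxygen on an aromatic ring, what the oxygen carries does matter in this assay: hydrogen and methyl could not be told apart, but acetyl separates from both, with a number 24.3 percentage points lower from compound 3 to compound 4 (beyond the scatter) and a number 26.1 percentage points lower from compound 2 to compound 4 (beyond the scatter) on the same shared core. An oxygen on the aromatic carbon is therefore not enough on its own to keep the higher numbers of compound 2 and compound 3, since acetoxy falls with dimethylamino, with a number 4.9 percentage points higher from compound 1 to compound 4 (within the scatter) as the step between them. Nothing available here accounts for the drop that comes with acetyl.

Open, going by these compounds, is whether the drop is particular to acetyl or extends to other groups on that oxygen, such as ethyl, benzoyl or carbamoyl. Also open, on these data alone, is whether a carboxylic acid or a fluorine on the aromatic carbon would group with compound 2 and compound 3 or with compound 1 and compound 4.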